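The source may hold more compounds than are shown below. What is called first, only, known or untested is meant among the compounds shown, and "the series" means these compounds.

Measured so far in a physicochemical assay for lipophilicity, at pH 7.4; a lower number here means a more polar compound, a higher number a more lipophilic compound:
- compound 1 `Cc1cc(C(N)=O)nn1Cc1cc(Cl)ccc1OCC(C)C`: 3.1
- compound 2 `Cc1cc(NC(=O)OCc2ccccc2)nn1Cc1cc(Cl)ccc1OCc1ccccc1`: 3.1

Compound 1 stands level with compound 2 within the scatter, and neither can be placed above the other in this assay. Going by the values given here, the two compounds differ in more than one place, so this pair gives no measured step to carry forward, and no other pair of measured compounds fills the gap.

The next compound is compound 3 `Cc1cc(NC(=O)OC(C)C)nn1Cc1cc(Cl)ccc1OCC(C)C`, which keeps the rest of compound 1 and changes one group on an aromatic carbon. There, (isopropoxycarbonyl)amino stands in place of carbamoyl ((isopropoxycarbonyl)amino in place of carbamoyl on an aromatic carbon). Among the compounds with values here, with no measured precedent for this exchange, the expectation rests on the structural change alone, and the uncertainty is correspondingly wide. The entering group is the larger one and carries more carbon, so a rise in this assay is expected, beyond the scatter. The expected size is a number 1.10 log units higher from compound 1 to compound 3 (beyond the scatter) on this estimate. Compound 3 is estimated at 4.2 with an expected range from 3.6 to 4.8 in the coming measurement.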

Compound 3, distribution coefficient: > 3.7
Compound 3 gave a limit, no number (the forecaster's own chance of this, stated with the estimate: 5%); the middle value is on the limit's open side.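

In this assay compound 3 reads > 3.7, which is a limit of the assay and not a number. Going by these compounds alone, the series now has its only measured step, at the aromatic carbon of the five-membered aromatic ring with 2 nitrogen: (isopropoxycarbonyl)amino in place of carbamoyl gives a number at least 0.60 log units higher from compound 1 to compound 3 (beyond the scatter), so with the rest of compound 1 kept, the group at this position does move the read-out, a point the level pair of compound 1 and compound 2 could not settle. The step therefore has a lower bound and no upper bound, and its full size cannot be read, as the result rests on an assay limit: the limit of > 3.7 in this assay, at which 1 of the 3 values shown sits.

Open, going by these compounds, is how far this position can be taken in the other direction, for instance whether an amine or a carboxylic acid on the same aromatic carbon would stand clearly apart from compound 1 in this assay. Also open, on these data alone, is how the step divides between the carbons of the isopropyl part and the rest of the entering group, which a (methoxycarbonyl)amino group at this place would help to separate.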